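The source may report more compounds than this note shows. Statements on the series, on what has been measured and on what is new or still open speak of the compounds shown alone.

In a functional assay with Homo sapiens as the target (on this read-out lower numbers stand for stronger inhibition and higher numbers for weaker inhibition), three compounds that share one core and differ only in the group on an oxygen on a saturated carbon have been measured. Compound 1 `CC(C)[C@H](NC(=O)COc1cccc2ccccc12)C(=O)N[C@@H](CC(=O)O)C(=O)COc1cccc(F)c1` gives 12000 nM, compound 2 `CC(C)[C@H](NC(=O)COc1cccc2ccccc12)C(=O)N[C@@H](CC(=O)O)C(=O)COc1cc(F)cc(F)c1F` gives 11200 nM, and compound 3 `CC(C)[C@H](NC(=O)COc1cccc2ccccc12)C(=O)N[C@@H](CC(=O)O)C(=O)COc1c(Cl)cccc1Cl` gives 15300 nM. Compound 3 therefore stands level with the other two, within the scatter of repeated measurements.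

Among the compounds with values here, the next compound, compound 4 `CC(C)[C@H](NC(=O)COc1cccc2ccccc12)C(=O)N[C@@H](CC(=O)O)C(=O)COc1cccc(C(F)(F)F)c1F`, keeps the core and changes only that group: 2-fluoro-3-(trifluoromethyl)phenyl in place of 2,6-dichlorophenyl on an oxygen on a saturated carbon. In words, 2-fluoro-3-(trifluoromethyl)phenyl comes in place of 2,6-dichlorophenyl. Within the data shown here, no measured compound carries trifluoromethyl, so the data offer no direct test of it. Still, three measured steps swap the same group, and they are the best available guide. With a 1.1-fold lower number from compound 1 to compound 2 (0.03 log units; within the scatter), a 1.3-fold higher number from compound 1 to compound 3 (0.11 log units; within the scatter) and a 1.4-fold higher number from compound 2 to compound 3 (0.14 log units; within the scatter), all within the scatter, no step beyond the scatter is expected in this assay here. The expected outcome is a 1.2-fold lower number from compound 3 to compound 4 (0.07 log units; within the scatter). Compound 4 is estimated at 13000 nM, with an expected range from 7000 nM to 24000 nM.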

Compound 4, half-maximal inhibitory concentration: 18200 nM
Compound 4: middle estimate off by 1.4-fold (0.15 log units), on the low side; the measured number falls inside the stated range.
By their numbers in this assay, from the lowest: compounds 2, 1, 3 and 4 (each within the scatter of the next).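

In this assay, within the data shown here, bringing in 2-fluoro-3-(trifluoromethyl)phenyl, the first group here to carry trifluoromethyl, gives steps that all stay within the scatter (a 1.2-fold higher number from compound 3 to compound 4 (0.08 log units; within the scatter); a 1.6-fold higher number from compound 2 to compound 4 (0.21 log units; within the scatter); a 1.5-fold higher number from compound 1 to compound 4 (0.18 log units; within the scatter)). The flat picture seen with fluorine and chlorine on the ring therefore extends to this group of 11 heavy atoms, and all four compounds remain level at this position on an oxygen on a saturated carbon. No supporting measurement is available to explain this result.

Going by these compounds, what an amine or a carboxylic acid on the ring, or a longer chain in place of the ring, would do at this oxygen remains open. The compounds shown also cannot tell whether any group here can move the number beyond the scatter.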